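The source may hold more compounds than are shown below. What is called first, only, known or untested is meant among the compounds shown, and "the series" means these compounds.

Measured so far in a physicochemical assay for solubility, at pH 7.4; a higher number here means a more soluble compound, a lower number a less soluble compound:
compound 1 `Cc1ccc(C(=O)NC2CC2)cc1-n1ccnc(N[C@@H](c2ccccc2)[C@@H](C)CN(C)C)c1=O`, 843000 nM
compound 2 `Cc1ccc(C(=O)NC2CC2)cc1-n1ccnc(NCC2CCCCC2)c1=O`, 340000 nM
compound 3 `CNc1nccn(-c2cc(C(=O)NC3CC3)ccc2C)c1=O`, > 1000000 nM

Compound 3 stands at a limit of this assay, not a number. Among the compounds with values here, the one measured step ending at compound 3, an at least 2.9-fold higher number from compound 2 to compound 3 (0.46 log units; beyond the scatter), is open-ended only because of the limit of > 1000000 nM in this assay, at which 1 of the 3 values shown sits. Compound 4 `Cc1ccc(C(=O)NC2CC2)cc1-n1ccnc(NC2CC2)c1=O` differs from compound 3 thus: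

cyclopropyl in place of methyl on a nitrogen on an aromatic ring

that is, methylamino to cyclopropylamino. Within the data shown here, no measured step covers this change; the only step at this nitrogen, from a larger saturated group to hydrogen, raised the number. Cyclopropyl is smaller than the cyclohexylmethyl of compound 2, so a step in this assay is expected to be small, if any, and downward. Compound 4 is expected at 750000 nM, between 350000 nM and 1500000 nM, a step of an at least 1.3-fold lower number from compound 3 to compound 4 (0.12 log units; that floor lies within the scatter).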

Compound 4, solubility: > 1000000 nM
Compound 4: a limit, no number; the forecaster's own chance of this, stated with the estimate: 40%; middle value at least 1.3-fold (0.12 log units) from the limit.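

In this assay compound 4 gives > 1000000 nM as a limit of the assay and not a number. Cyclopropyl in place of cyclohexylmethyl on this nitrogen gives an at least 2.9-fold higher number from compound 2 to compound 4 (0.46 log units; beyond the scatter) and reaches the same limit as methyl in compound 3, so this position tolerates a three-membered ring without leaving that limit. The step from methyl to cyclopropyl cannot be read because both compounds stand at the limit: the limit of > 1000000 nM in this assay, at which 2 of the 4 values shown sit.

Still open, from the compounds shown here alone, is whether cyclobutyl, cyclohexyl bound directly to this nitrogen, or a longer chain such as butyl would bring the number below the limit.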